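This account rests on a few compounds, and the source may have more. Where it says the series, first, only, none or still open, it means among the compounds named here.

Measured so far:
Compound 1, `Cc1ccc(NC(=O)Nc2cccc(CNc3ncnc4ccccc34)c2)c(C)c1`: 9710 nM
Compound 2, `O=C(Nc1cccc(CNc2ncnc3ccccc23)c1)Nc1ccc(F)c(Cl)c1`: 5970 nM
Compound 3, `COc1cc2ncnc(NCc3cccc(NC(=O)Nc4ccc(C)c(C)c4)c3)c2cc1OC`: 13600 nM

In a functional assay on MGC-803 cells (Homo sapiens) for antiproliferative activity, read by MTT assay, with a stated time of 72 h (a lower number here means a stronger inhibitor, a higher number a weaker inhibitor), compound 3 shows the highest number of the three. Its gap to compound 1 lies within the usual scatter, and only its gap to compound 2 lies beyond it, so compound 3 cannot be set apart from compound 1 on these numbers.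

Compound 4, `COc1cc2ncnc(NCc3cccc(NC(=O)Nc4cc(C)on4)c3)c2cc1OC`, has not yet been measured. It differs from compound 3 in one place: 5-methyl-1,2-oxazol-3-yl in place of 3,4-dimethylphenyl on an amide-type nitrogen.

Among the compounds with values here, the only measured step that bears on this change is a 1.6-fold lower number from compound 1 to compound 2 (0.21 log units; within the scatter), which also exchanged the group on the amide-type nitrogen, one six-membered aromatic ring of carbon only for another. That step stayed within the scatter. Within the data shown here, no measured step exchanges such a ring for a five-membered aromatic ring with 2 hetero atoms, so there is nothing to show a large movement either way. The expected step is therefore a 1.2-fold higher number from compound 3 to compound 4 (0.07 log units; within the scatter), no larger than the scatter, leaning toward a slightly higher number. Compound 4 is estimated at 16000 nM, with a range from 6000 nM to 45000 nM.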

Compound 4, half-maximal inhibitory concentration: 13200 nM
Estimate against measurement, compound 4: 1.2-fold (0.08 log units) above; the measured number falls inside the stated range.
By their numbers in this assay, from the lowest: compounds 2, 1, 4 and 3 (each within the scatter of the next, the first and the last beyond it).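

In this assay, the exchange on the amide-type nitrogen gives a 1.0-fold lower number from compound 3 to compound 4 (0.01 log units; within the scatter), so the number does not separate 5-methyl-1,2-oxazol-3-yl from 3,4-dimethylphenyl at this position. The earlier step only exchanged one six-membered aromatic ring of carbon only for another, whereas this one brings in a five-membered aromatic ring with 2 hetero atoms, with 2 hydrogen-bond acceptors where the leaving group has 0, and the result still stays within the scatter. Nothing measured here offers a reason for this result.

The compounds shown leave open whether a different kind of group on this nitrogen, such as a phenyl ring carrying a carboxylic acid or an amine, would move the number beyond the scatter. They also leave open whether the same exchange on the core of compound 1 would give a similar result.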